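Swapping Bromine for Methyl on a Trimethoxyphenyl Amide

A few compounds are considered here, and "the series" means these few. Any claim that something is new, unique, unknown or untested is made for them only; others in the source may bear on it.

Compound 1 `COc1ccc(CN(C(=O)C(C)Br)c2cc(OC)c(OC)c(OC)c2)cc1O` carries a shared core with an amide whose chain bears a bromo group. In a functional assay on HCT-116 cells (Homo sapiens) for inhibition, read by MTT assay, with a stated time of 48 h (on this read-out higher numbers stand for weaker inhibition and lower numbers for stronger inhibition), compound 1 gives 140 nM, the lowest of the two numbers measured here. Compound 2 `C/C=C/C(=O)N(Cc1ccc(OC)c(Br)c1)c1cc(OC)c(OC)c(OC)c1` is built on the same core but with a different amide and a different substituted benzyl group, and in this assay compound 2 gives 2800 nM, a higher number that lies beyond the usual scatter of this assay.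

Compound 3 `COc1ccc(CN(C(=O)C(C)C)c2cc(OC)c(OC)c(OC)c2)cc1O` is the next compound to be tested. It differs from compound 1 in one place: methyl in place of bromo on a saturated chain carbon bound to a carbonyl carbon and a saturated chain carbon. For the measured compounds named here, no measured pair shows this exact exchange, so the size of its effect is unknown. The loss of the bromo group is expected to cost some inhibition, with a step from compound 1 to compound 3 estimated at a 4.3-fold higher number from compound 1 to compound 3 (0.63 log units; beyond the scatter) in this assay. Compound 3 is therefore expected to give about 600 nM, plausibly between 150 nM and 3000 nM.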

Compound 3, half-maximal inhibitory concentration: 310 nM
Estimate against measurement, compound 3: 1.9-fold (0.29 log units) above; the range from low to high includes it.
By their numbers in this assay, from the lowest: compound 1; then compound 3; then compound 2.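

In this assay, methyl in place of bromo on this saturated chain carbon gives a 2.2-fold higher number from compound 1 to compound 3 (0.35 log units; beyond the scatter), so the bromo group is not essential for inhibition: compound 3, with its isopropylcarbonyl group, still reaches 310 nM. The step is modest but beyond the usual scatter, so in this one pair the bromo-bearing compound 1 keeps a real edge over its methyl partner. Nothing available explains this difference between the two groups.

This single pair cannot show whether a chloro group, an amine or a longer chain at the same carbon would give a lower or higher number. It also leaves open whether the same exchange would give a similar step with a different substituted benzyl group on the shared core.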